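Swapping the Five-Membered Ring on the Shared Core

The compounds below may be only part of what the source reports. "The series", "measured", "known", "first", "only" and "open" are said of these compounds alone.

Compound 3 `CC(C)(C)C(=O)C1=C(O)C(=O)N(c2ccc(-c3ccon3)cc2)C1c1ccccc1OCCO` stands second highest of the three numbers in an ADME assay on the whole organism (Rattus norvegicus) for metabolic stability (a lower number here means that the compound disappears faster, a higher number that the compound lasts longer), with compound 3 giving 2.1 h. Its nearest neighbour is compound 1 `COc1ccccc1C1C(C(=O)C(C)(C)C)=C(O)C(=O)N1c1ccc(-c2ccon2)cc1`, which gives 2.6 h; a 1.2-fold lower number from compound 1 to compound 3 (0.09 log units; within the scatter). Furthest away is compound 2 `COc1ccc(C(=O)C2=C(O)C(=O)N(c3ccc(-c4ccon4)cc3)C2c2ccccc2OCCO)cc1`, which gives 0.5 h; a 4.2-fold higher number from compound 2 to compound 3 (0.62 log units; beyond the scatter).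

Compound 4 `CC(C)(C)C(=O)C1=C(O)C(=O)N(c2ccc(-c3ccsc3)cc2)C1c1ccccc1OCCO` differs from compound 3 by thiophen-3-yl in place of 1,2-oxazol-3-yl on an aromatic carbon. Neither measured step touches that place: the step from compound 1 to compound 3 changed a saturated chain carbon bound to an oxygen on an aromatic ring, and the step from compound 2 to compound 3 changed the group on a carbonyl carbon. Nothing measured here shows how this assay answers an exchange of the five-membered ring, so no step beyond the scatter is expected in either direction, and the estimate rests on compound 3 with widened bounds.

Compound 4 is therefore estimated at 2 h, with a range from 0.8 h to 4.5 h. The expected step is a 1.1-fold lower number from compound 3 to compound 4 (0.02 log units; within the scatter), within the scatter.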

Compound 4, half-life: 3.3 h
Compound 4: middle estimate off by 1.7-fold (0.22 log units), on the low side; low and high end bracket the measured number.
By their numbers in this assay, from the lowest: compound 2; then compounds 3, 1 and 4 (each within the scatter of the next).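

Among the compounds shown here, the exchange of 1,2-oxazol-3-yl for thiophen-3-yl, on an aromatic carbon para to a large group, gives the first reading at this position in this assay: a 1.6-fold higher number from compound 3 to compound 4 (0.20 log units; within the scatter), so the step stays inside the usual spread of repeats. This place therefore accepts a five-membered aromatic ring with one hetero atom, sulfur, in exchange for one with two hetero atoms, without a step that stands clear of the scatter. No measurement at hand bears on why the number responds as it does to this exchange.

The compounds shown leave open how this assay would answer an amine or a carboxylic acid on this aromatic carbon in place of the five-membered ring. Also open, going by these compounds, is whether the same exchange would read alike with 4-methoxyphenyl on the carbonyl carbon, as in compound 2.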